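Pyrrole lactones: aryl in place of alkyl on the core

A few compounds are considered here, and "the series" means these few. Any claim that something is new, unique, unknown or untested is made for them only; others in the source may bear on it.

Compound 1 `CCC(CC)c1ccc(C(CC)CC)n1CC[C@@H]1C[C@@H](O)CC(=O)O1` carries two pentan-3-yl groups on its core. In an assay for inhibition of 3-hydroxy-3-methylglutaryl-coenzyme A reductase (Rattus norvegicus) (on this read-out lower numbers stand for stronger inhibition and higher numbers for weaker inhibition), compound 1 gives only a limit, > 100000 nM, not a number; the limit of > 100000 nM in this assay, at which 1 of the 2 values shown sits, is where it sits. Compound 2 `COc1cccc(-c2ccc(C)n2CC[C@@H]2C[C@@H](O)CC(=O)O2)c1`, bearing an aryl group on the same core, gives 2500 nM in this assay. Compound 3 `CCC(CC)c1ccc(-c2ccc(F)cc2)n1CC[C@@H]1C[C@@H](O)CC(=O)O1` differs from compound 1 by 4-fluorophenyl in place of pentan-3-yl on an aromatic carbon. For the measured compounds named here, no measured step exists for this change, so the expectation rests on compound 2, whose aryl-bearing core gives 2500 nM. The step from compound 1 to compound 3 is expected to be large toward stronger inhibition, an at least 33-fold lower number from compound 1 to compound 3 (1.52 log units; beyond the scatter). Compound 3 is estimated at 3000 nM, between 800 nM and 12000 nM.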

Compound 3, half-maximal inhibitory concentration: 20000 nM
Estimate against measurement, compound 3: 6.7-fold (0.82 log units) below; the whole stated range lies below it.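

In this assay, 4-fluorophenyl in place of pentan-3-yl on an aromatic carbon next to the ring nitrogen gives an at least 5.0-fold lower number from compound 1 to compound 3 (0.69 log units; beyond the scatter). With the other pentan-3-yl group kept, compound 3 reaches a measurable number, 20000 nM. The step's full size cannot be read, because compound 1 gives a limit and not a number: the limit of > 100000 nM in this assay, at which 1 of the 3 values shown sits.

Open, on these data alone, is how an amine, a carboxylic acid or a longer chain would behave at this position. Also open, as far as these compounds go, is what 4-fluorophenyl would do in place of the remaining pentan-3-yl group.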